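From bromo to methyl: compound 1 and compound 3

A few compounds are considered here, and "the series" means these few. Any claim that something is new, unique, unknown or untested is made for them only; others in the source may bear on it.

Measured so far in a functional assay on thoracic aorta (Rattus norvegicus, strain Wistar), with a stated time of 15 min (a higher number here means that more compound is needed for the effect, a lower number that less compound is needed), are these values:
- compound 1 `Cc1ccc(S(=O)(=O)N(C)C(=O)NC(C)c2cc(Br)ccc2OCc2ccccc2)cc1` gives 67100 nM
- compound 2 `COc1ccc(Br)cc1C(C)NC(=O)N(C)S(=O)(=O)c1ccc(C)cc1` gives 19100 nM

Compound 1 holds the higher of these two numbers, and the gap to compound 2 lies beyond the scatter. Compound 3 `Cc1ccc(S(=O)(=O)N(C)C(=O)NC(C)c2cc(C)ccc2OCc2ccccc2)cc1` departs from compound 1 by methyl in place of bromo on an aromatic carbon with methyl in place of bromo on an aromatic carbon, para to a benzyloxy group. Within the data shown here, the only measured step is modest, a 3.5-fold lower number from compound 1 to compound 2 (0.55 log units; beyond the scatter) and it concerns hydrogen in place of phenyl at a different place. Among the measured compounds shown here, no measured pair tests bromo against methyl, so no step beyond the scatter is expected in this assay and no direction can be favoured. The estimated outcome is a 1.1-fold lower number from compound 1 to compound 3 (0.05 log units; within the scatter) as the expected step. Compound 3 is expected at 60000 nM with an estimated range from 25000 nM to 130000 nM in this read-out.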

Compound 3, half-maximal effective concentration: 181000 nM
Compound 3: the middle estimate sits 3.0-fold (0.48 log units) below what was measured; the measured number lies above the stated range.
By their numbers in this assay, from the lowest: compound 2; then compound 1; then compound 3.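

In this assay, the change from bromo to methyl on this aromatic carbon, para to a benzyloxy group, gives a 2.7-fold higher number from compound 1 to compound 3 (0.43 log units; beyond the scatter). Among these compounds, this is the first measured sign that the position responds to substitution, as the earlier step concerned a different place, and here the bromo compound has the lower number, even though each group is a single heavy atom and neither carries a hydrogen-bond donor or acceptor. Nothing measured here accounts for the direction or size of this step.

As far as these compounds go, it remains open whether methyl in place of bromo would move the number in the same way on compound 2. From the compounds shown here alone, it is also open how another group at this carbon, such as chloro, a nitrile or an amine, would compare with bromo and methyl.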